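A few compounds are considered here, and "the series" means these few. Any claim that something is new, unique, unknown or untested is made for them only; others in the source may bear on it.

Compound 1 `COC(=O)[C@@]1(C)CCC=C2[C@@H]1CC[C@@H](C)[C@]2(C)Cc1c[nH]c2ccccc12` carries an indole attached through a single carbon to a bicyclic core that also bears a methyl ester. Going by the values given here, in a functional assay on WiDr cells (Homo sapiens) for inhibition, read by sulforhodamine B assay, with a stated time of 48 h (a higher number here means a weaker inhibitor of growth, a lower number a stronger inhibitor of growth), compound 1 gives 8700 nM, the lower of the two numbers recorded so far; its only neighbour is compound 2 `COC(=O)[C@@]1(C)CCC=C2[C@@H]1CC[C@@H](C)[C@]2(C)Cc1c[nH]c2ccc(Cl)cc12`, which gives 20000 nM in this assay, and the step of a 2.3-fold higher number from compound 1 to compound 2 (0.36 log units; beyond the scatter) came with a chloro in place of hydrogen on an aromatic carbon.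

Compound 3 `COC(=O)[C@@]1(C)CCC=C2[C@@H]1CC[C@@H](C)[C@]2(C)Cc1c(C=O)[nH]c2ccccc12` differs from compound 1 by formyl in place of hydrogen on an aromatic carbon. Among the compounds with values here, no measured step touches the same position or the same kind of group; the step from compound 1 to compound 2 concerns a different carbon and a different substituent, so it offers only the hint that small additions to the indole have so far shifted the number modestly, and in the weaker direction. With that thin footing, the expected change is a 1.1-fold higher number from compound 1 to compound 3 (0.06 log units; within the scatter), and compound 3 is estimated at 10000 nM in this assay, within a range from 3000 nM to 35000 nM.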

Compound 3, concentration for 50% growth inhibition: 20000 nM
Compound 3: middle estimate off by 2.0-fold (0.30 log units), on the low side; low and high end bracket the measured number.
By their numbers in this assay, from the lowest: compound 1; then compounds 2 and 3 (each within the scatter of the next).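

Placing formyl on the aromatic carbon next to the ring nitrogen gives a 2.3-fold higher number from compound 1 to compound 3 (0.36 log units; beyond the scatter) in this assay, which shows that this position of the five-membered aromatic ring also responds to substitution, and that this change leads to a weaker inhibitor of growth. Going by these compounds alone, until now, the only change seen was a chloro on a different carbon, and compound 1 remains the strongest inhibitor of growth of the three. No measurement at hand explains why formyl at this position has this effect.

On these data alone, whether a smaller or different group on this same carbon, such as a methyl, an amine or a carboxylic acid, would also raise the number remains open. As far as these compounds go, it is also open whether any addition to the indole can give a number lower than that of compound 1.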